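This account rests on a few compounds, and the source may have more. Where it says the series, first, only, none or still open, it means among the compounds named here.

Values measured in a functional assay on MCF7 cells (Homo sapiens), read by MTT assay, with a stated time of 48 h; on this read-out lower numbers stand for stronger inhibition and higher numbers for weaker inhibition:
- compound 1 `CCn1c(C(=O)NCCN(C)C)ccc1C(CC)(CC)c1ccc(OCC(=O)C(C)(C)C)c(C)c1`: 520 nM
- compound 2 `CCN(CC)CCCNC(=O)c1ccc(C(CC)(CC)c2ccc(OCC(=O)C(C)(C)C)c(C)c2)n1CC`: 530 nM
- compound 3 `CCn1c(C(=O)NCCN)ccc1C(CC)(CC)c1ccc(OCC(=O)C(C)(C)C)c(C)c1`: 75 nM

Among these, compound 3 has the lowest number, and its gap to each of the other two lies beyond the usual scatter. Compound 4 `CCn1c(C(=O)N(C)CC(=O)O)ccc1C(CC)(CC)c1ccc(OCC(=O)C(C)(C)C)c(C)c1` has not yet been measured. The change leading to it is (carboxymethyl)(methyl)amino in place of (2-aminoethyl)amino on a carbonyl carbon.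

Three measured steps offer some guidance, and each swaps one amino group for another. The first, a 1.0-fold higher number from compound 1 to compound 2 (0.01 log units; within the scatter), changes nothing measurable. The other two are modest but real: a 6.9-fold lower number from compound 1 to compound 3 (0.84 log units; beyond the scatter) and a 7.1-fold lower number from compound 2 to compound 3 (0.85 log units; beyond the scatter). Within the data shown here, no measured compound carries the carboxymethyl group, and all three keep the amide hydrogen that compound 4 lacks, so none of these steps measures the new change directly.

Compound 3 at 75 nM is the low point of this small set, so a move away from it is more likely upward, by about the size of those modest steps. The expected change is a 5.3-fold higher number from compound 3 to compound 4 (0.73 log units; beyond the scatter), though this is uncertain. The estimate for compound 4 is 400 nM, with an expected range of 80 nM to 2500 nM.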

Compound 4, half-maximal inhibitory concentration: 28600 nM
The estimate for compound 4 lay 72-fold (1.85 log units) below the measured number; the measured number lies above the stated range.
By their numbers in this assay, from the lowest: compound 3; then compounds 1 and 2 (each within the scatter of the next); then compound 4.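

In this assay, the group on this carbonyl carbon proves able to shift the number far more than the earlier swaps among amino groups suggested: (carboxymethyl)(methyl)amino in place of (2-aminoethyl)amino gives a 380-fold higher number from compound 3 to compound 4 (2.58 log units; beyond the scatter). The steps from the other two amine-bearing side chains are also large, with a 55-fold higher number from compound 1 to compound 4 (1.74 log units; beyond the scatter) and a 54-fold higher number from compound 2 to compound 4 (1.73 log units; beyond the scatter), so the result does not depend on which of the three amine-bearing compounds serves as the reference. No measurement available here explains why this change has such a large effect.

The new group differs in two ways, since it brings a carboxylic acid and also a methyl group where the other compounds keep the amide hydrogen, and the compounds shown cannot tell whether the rise comes from one of these features or from both together. A (carboxymethyl)amino group, which has the acid and keeps the amide hydrogen, and a (2-aminoethyl)(methyl)amino group, which has the methyl and keeps the amine, would pull these two features apart on the same carbonyl carbon.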